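The source may report more compounds than this note shows. Statements on the series, on what has been measured and on what is new or still open speak of the compounds shown alone.

Three compounds share one core, one chain ending in an amide that carries a sulfonamide-bearing ring, and differ only in the aromatic group attached to a nitrogen on that core. Compound 1 `COc1cc2ncnc(Nc3ccc(Cl)c(C(F)(F)F)c3)c2cc1OCCCCC(=O)Nc1ccc(S(N)(=O)=O)cc1` carries a 4-chloro-3-(trifluoromethyl)phenyl group there, and in a functional assay on NCI-H1975 cells (Homo sapiens) for antiproliferative activity, read by MTT assay, with a stated time of 72 h (on this read-out higher numbers stand for weaker inhibition and lower numbers for stronger inhibition), compound 1 gives 3220 nM. Compound 2 `COc1ccc(Nc2ncnc3cc(OC)c(OCCCCC(=O)Nc4ccc(S(N)(=O)=O)cc4)cc23)cc1` carries a 4-methoxyphenyl group instead, and in this assay compound 2 gives 30200 nM. Compound 3 `COc1cc2ncnc(Nc3ccc(F)c(Br)c3)c2cc1OCCCCC(=O)Nc1ccc(S(N)(=O)=O)cc1` carries a 3-bromo-4-fluorophenyl group, and in this assay compound 3 gives 31600 nM, the highest of the three numbers; its gap to compound 2 lies within the scatter, while the step of a 9.8-fold higher number from compound 1 to compound 3 (0.99 log units; beyond the scatter) lies beyond it.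

Compound 4 `COc1cc2ncnc(Nc3cccc(Cl)c3F)c2cc1OCCCCC(=O)Nc1ccc(S(N)(=O)=O)cc1` is the next member: 3-chloro-2-fluorophenyl in place of 3-bromo-4-fluorophenyl on a nitrogen on an aromatic ring. The measured steps that bear on this change are those that swap the same aromatic group. The step of a 9.8-fold higher number from compound 1 to compound 3 (0.99 log units; beyond the scatter) and the step of a 9.4-fold higher number from compound 1 to compound 2 (0.97 log units; beyond the scatter) show that this group can shift the number by a modest but clear amount, whereas the step of a 1.0-fold higher number from compound 2 to compound 3 (0.02 log units; within the scatter) shows two different groups giving the same number. For the measured compounds named here, compound 4 keeps a chlorine, as compound 1 does, but lacks the trifluoromethyl group, and no measured pair matches it exactly. Compound 4 is therefore expected to fall between those outcomes, with a step of a 2.6-fold lower number from compound 3 to compound 4 (0.42 log units; beyond the scatter) toward a lower number. The estimate for compound 4 in this assay is 12000 nM, with a range from 2500 nM to 45000 nM.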

Compound 4, half-maximal inhibitory concentration: 6930 nM
Beside the measured number, compound 4's estimate is 1.7-fold (0.24 log units) above it; low and high end bracket the measured number.
By their numbers in this assay, from the lowest: compound 1; then compound 4; then compounds 2 and 3 (each within the scatter of the next).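

For the compounds shown here, compound 4 adds a level that the earlier compounds did not show. a 4.6-fold lower number from compound 3 to compound 4 (0.66 log units; beyond the scatter) and a 4.4-fold lower number from compound 2 to compound 4 (0.64 log units; beyond the scatter) place it clearly apart from the two compounds whose numbers lie within the scatter of each other, while a 2.2-fold higher number from compound 1 to compound 4 (0.33 log units; beyond the scatter) keeps it apart from compound 1 as well. In this assay this position therefore gives three separate levels among four groups, not simply compound 1 against the rest. The change from 3-bromo-4-fluorophenyl to 3-chloro-2-fluorophenyl also leaves the heavy-atom count the same and keeps one fluorine, so even a swap between two equally sized groups, each with two halogens, can move the number beyond the scatter.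

That swap changes both the halogen and where the fluorine sits, so the compounds shown leave open which of the two matters, and a 3-chloro-4-fluorophenyl group on the same nitrogen would separate them. Nothing available here explains why these groups fall in this order.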